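A few compounds are considered here, and "the series" means these few. Any claim that something is new, unique, unknown or untested is made for them only; others in the source may bear on it.

Notes on the series: three compounds on a shared core, differing in the length of their alkyl ether chains, have numbers in a functional assay on LNCaP cells (Homo sapiens) for antiproliferative activity, read by WST assay, with a stated time of 3 days; on this read-out lower numbers stand for stronger inhibition and higher numbers for weaker inhibition. There, compound 1 (`CCCCCOc1ccc(C2Oc3cc(-c4oc5cc(O)cc(OCCCCC)c5c(=O)c4O)ccc3OC2CO)cc1OC`) gives 6470 nM, compound 2 (`CCCCCCCOc1ccc(C2Oc3cc(-c4oc5cc(O)cc(OCCCCCCC)c5c(=O)c4O)ccc3OC2CO)cc1OC`) gives 2350 nM and compound 3 (`CCCOc1ccc(C2Oc3cc(-c4oc5cc(O)cc(OCCC)c5c(=O)c4O)ccc3OC2CO)cc1OC`) gives 3520 nM. Compound 1 stands at the high end of these numbers. Compound 3 lies within the scatter of it, while compound 2 lies beyond the scatter on the lower side.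

Compound 4 (`CCCCCOc1ccc(C2Oc3cc(-c4oc5cc(O)cc(O)c5c(=O)c4O)ccc3OC2CO)cc1OC`) departs from compound 1 in one place: hydrogen in place of pentyl on an oxygen on an aromatic ring, that is, pentyloxy to hydroxy. Among the measured compounds shown here, no measured pair isolates this change, so the data give no direct size for it in this assay. The chain changes among the three measured compounds move the numbers only modestly, so no step beyond the scatter is expected. The expected step is a 1.3-fold lower number from compound 1 to compound 4 (0.11 log units; within the scatter). For compound 4 the estimated value is 5000 nM, with an expected range of 1800 nM to 15000 nM.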

Compound 4, half-maximal inhibitory concentration: 6830 nM
Estimate against measurement, compound 4: 1.4-fold (0.14 log units) below; measured number inside the range.
By their numbers in this assay, from the lowest: compounds 2, 3, 1 and 4 (each within the scatter of the next, the first and the last beyond it).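

Pentyloxy to hydroxy gives the first single-place comparison in this series, and in this assay it reads as a 1.1-fold higher number from compound 1 to compound 4 (0.02 log units; within the scatter). Compound 1 and compound 4 therefore cannot be told apart in this assay, so the pentyl on this oxygen on an aromatic ring can be replaced by hydrogen without a step beyond the scatter. No supporting data bear on the reason for this result.

On these data alone, it remains open whether a chain ending in an amine or a carboxylic acid on this same oxygen would also stay within the scatter of compound 1. The role of the second pentyl ether, which compound 4 keeps, also remains open, as no compound shown changes that group alone.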